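Halogen swap on the benzyl ring of a hydroxamate series

The compounds below may be only part of what the source reports. "The series", "measured", "known", "first", "only" and "open" are said of these compounds alone.

Compound 1 `O=C(CCC1=CCN(Cc2cccc(Br)c2)C1=O)NO` gives 4280 nM in a functional assay on NUGC-3 cells (Homo sapiens) for inhibition, read by sulforhodamine B assay; on this read-out higher numbers stand for weaker inhibition of growth and lower numbers for stronger inhibition of growth. Compound 3 `O=C(CCC1=CCN(Cc2cccc(Cl)c2)C1=O)NO` carries chloro in place of bromo on an aromatic carbon and gives 4280 nM in this assay; the step of no change at the digits printed from compound 1 to compound 3 (within the scatter). Compound 2 `O=C(CCC1=CCN(Cc2ccc(Br)cc2)C1=O)NO` has the same atoms as compound 1 joined differently; the difference between the two cores is not broken down here, and in this assay compound 2 gives "not determined" (no result reported), so no result was reported for it. Compound 4 `O=C(CCC1=CCN(Cc2ccc(Cl)cc2)C1=O)NO` is the unmeasured partner of compound 2, bearing (chloro in place of bromo on an aromatic carbon). This is the same kind of change as from compound 1 to compound 3, but the place differs: meta to a large group there, para to a large group here. With compound 1 and compound 3 both at the same level, the step from compound 2 to compound 4 in this assay is expected to be small, though compound 2 itself has no number to anchor it. Compound 4 is estimated at 4300 nM, range 1500 nM to 12000 nM.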

Compound 4, concentration for 50% growth inhibition: 4280 nM
Beside the measured number, compound 4's estimate is 1.0-fold (0.00 log units) above it, within the range that was stated.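

Going by these compounds alone, compound 2 has no reported result in this assay, so no step to compound 4 can be read. Nothing available explains the result for compound 4. From the compounds shown here alone, whether bromo and chloro differ when para to a large group stays open.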